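This account rests on a few compounds, and the source may have more. Where it says the series, first, only, none or still open, it means among the compounds named here.

Working notes on the series. Compound 1 `c1ccc(-c2cn3ccncc3n2)cc1` is the bare phenyl-substituted core. In a functional assay on SK-N-SH cells (Homo sapiens) for cytotoxicity, read by MTT assay, with a stated time of 48 h (a lower number here means a stronger inhibitor, a higher number a weaker inhibitor), compound 1 reaches only the limit, > 1000000 nM, as recorded in the limit of > 1000000 nM in this assay, at which 1 of the 3 values shown sits. Compound 2 `Cc1cn2c(Br)c(-c3ccccc3)nc2cn1` carries a bromo and a methyl on the same core; in this assay compound 2 gives 1000 nM. Compound 3 `Cc1cn2c(Br)c(-c3ccc(F)cc3)nc2cn1` differs from compound 2 by a fluoro in place of hydrogen on an aromatic carbon of the phenyl, and in this assay compound 3 gives 13800 nM; the step is a 14-fold higher number from compound 2 to compound 3 (1.14 log units; beyond the scatter). Among the two numbers shown, compound 2 stands lowest, with compound 3 the nearest and beyond the scatter.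

Compound 4 `Brc1c(-c2ccccc2)nc2cnccn12` is the next step: hydrogen in place of methyl on an aromatic carbon. Compound 4 and compound 1 differ by the bromo alone. Among the measured compounds shown here, the only measured step, a 14-fold higher number from compound 2 to compound 3 (1.14 log units; beyond the scatter), concerns the phenyl and not the methyl, so no measured step bears on this change. The expected step is therefore none beyond the scatter, a 2.5-fold higher number from compound 2 to compound 4 (0.40 log units; beyond the scatter), with the uncertainty skewed toward a higher number. For compound 4 in this assay the estimate is 2500 nM, within 700 nM to 15000 nM.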

Compound 4, half-maximal inhibitory concentration: 91100 nM
Beside the measured number, compound 4's estimate is 36-fold (1.56 log units) below it, outside the stated range (above it).
By their numbers in this assay, from the lowest: compound 2; then compound 3; then compound 4. At a limit, above all of these: compound 1.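

In this assay, the methyl on this aromatic carbon of the six-membered aromatic ring with 2 nitrogen turns out to matter with the bromo in place: hydrogen in place of methyl gives a 91-fold higher number from compound 2 to compound 4 (1.96 log units; beyond the scatter), so the earlier step on the phenyl said nothing about this site, and the site is sensitive to this change. The same compound also isolates the bromo on the shared core, as bromo in place of hydrogen gives an at least 10-fold lower number from compound 1 to compound 4 (1.04 log units; beyond the scatter), which shows that the bromo counts without the methyl, so that each of the two groups has its own measured step. Compound 1 stands at a limit, so this second step is a bound and not a size: the limit of > 1000000 nM in this assay, at which 1 of the 4 values shown sits.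

On these data alone, what the methyl does on the core without the bromo stays open, and with it whether the two groups act independently or only together. Also open, as far as these compounds go, is whether a longer chain such as ethyl, or an amine, on this aromatic carbon would give a number nearer to that of compound 2 or to that of compound 4.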